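The source may hold more compounds than are shown below. What is called first, only, known or untested is meant among the compounds shown, and "the series" means these compounds.

Measured compounds:
compound 1, `O=C1C=COC(/C=C/c2ccc(C(F)(F)F)cc2)C1`: 58.2 uM
compound 2, `COc1ccc(/C=C/C2CC(=O)C=CO2)cc1`: 87.4 uM

Going by the values given here, in a functional assay on OVCAR-3 cells (Homo sapiens) for inhibition, read by sulforhodamine B assay, with a stated time of 48 h (on this read-out higher numbers stand for weaker inhibition of growth and lower numbers for stronger inhibition of growth), compound 2 gives 87.4 uM, and the only companion is compound 1 with 58.2 uM. Among the compounds with values here, the single step between them, a 1.5-fold higher number from compound 1 to compound 2 (0.18 log units; within the scatter), stays within the scatter, so the two values cannot be told apart on these data.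

Compound 3, `COc1ccc(/C=C/C2CC(=O)C=CO2)cc1OC`, has not yet been measured. It differs from compound 2 by methoxy in place of hydrogen on an aromatic carbon. Within the data shown here, no measured step involves a methoxy in place of hydrogen on an aromatic carbon, so nothing here bears directly on this change; the only step known, from compound 1 to compound 2, concerns a different group and was itself within the scatter.

With no guide pointing either way, the value of compound 3 in this assay is expected to stay near that of compound 2, the step of a 1.1-fold lower number from compound 2 to compound 3 (0.04 log units; within the scatter) being within the scatter. The estimate for compound 3 is 80 uM, with a range from 35 uM to 180 uM.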

Compound 3, concentration for growth inhibition (reported as GI): 74.3 uM
For compound 3 the middle estimate is 1.1-fold (0.03 log units) above the measured one; measured number inside the range.
By their numbers in this assay, from the lowest: compounds 1, 3 and 2 (each within the scatter of the next).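

In this assay, going by these compounds alone, methoxy placed on the aromatic carbon ortho to a methoxy group and meta to a group of 9 heavy atoms gives a 1.2-fold lower number from compound 2 to compound 3 (0.07 log units; within the scatter), the first measured reading at this position, and on these data the change cannot be told apart from no change. The earlier step, a 1.5-fold higher number from compound 1 to compound 2 (0.18 log units; within the scatter), concerned a different change on the same ring, so both single changes measured on this ring now lie within the scatter. Nothing further on hand bears on this result.

The compounds shown leave open whether an amine or a carboxylic acid on this carbon would shift the number beyond the scatter. They also leave open whether a longer chain in place of this methoxy would do so.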